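Swapping the dichlorophenyl arm of the lowest-lying compound

The source may report more compounds than this note shows. Statements on the series, on what has been measured and on what is new or still open speak of the compounds shown alone.

Measured compounds:
Compound 1 `COc1ccc(Cn2c(=O)nc(NCCNC(=N)N)n(Cc3ccc(I)cc3)c2=O)cc1`: 0.039 nM
Compound 2 `Cc1ccc(Cn2c(=O)nc(NCCNC(=N)N)n(Cc3ccc(Cl)c(Cl)c3)c2=O)cc1`: 0.0051 nM
Compound 3 `COc1ccc(Cn2c(=O)nc(NCCNC(=N)N)n(Cc3ccc(F)cc3)c2=O)cc1`: 0.036 nM

In a functional assay on the whole organism (strain C57Bl/6) for inhibition, with Mus musculus as the target, with a stated time of 180 min, at 48 degrees C (a higher number here means that more compound is needed for the effect, a lower number that less compound is needed), compound 2 stands at the lowest number of the three, and both other compounds lie beyond the scatter above it: compound 3 is nearest, compound 1 furthest. Among the compounds with values here, the one measured step, a 1.1-fold lower number from compound 1 to compound 3 (0.03 log units; within the scatter), concerns a change at the other benzyl arm, a halogen exchanged for another halogen, and it lies within the scatter. Within the data shown here, no measured step touches the part of compound 2 that changes here.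

Compound 4 `COc1ccc(Cn2c(NCCNC(=N)N)nc(=O)n(Cc3ccc(C)cc3)c2=O)cc1` differs from compound 2 by 4-methoxyphenyl in place of 3,4-dichlorophenyl on a saturated chain carbon bound to an aromatic nitrogen. Nothing measured bears directly on this exchange; what the numbers show is that compound 1 and compound 3, which carry a 4-methoxybenzyl group and a single halogen on the other benzyl group, both sit well above compound 2. Because compound 2 gives 0.0051 nM while compound 3 gives 0.036 nM, the expectation is that compound 4 moves upward, toward those two compounds, with a step of about a 4.9-fold higher number from compound 2 to compound 4 (0.69 log units; beyond the scatter) expected. The estimate for compound 4 is 0.025 nM, within a range from 0.006 nM to 0.1 nM.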

Compound 4, half-maximal effective concentration: 0.0044 nM
For compound 4 the middle estimate is 5.7-fold (0.75 log units) above the measured one; the whole stated range lies above it.
By their numbers in this assay, from the lowest: compounds 4 and 2 (each within the scatter of the next); then compounds 3 and 1 (each within the scatter of the next).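

In this assay the exchange of 3,4-dichlorobenzyl for 4-methoxybenzyl on a saturated chain carbon bound to an aromatic nitrogen comes out as a 1.2-fold lower number from compound 2 to compound 4 (0.06 log units; within the scatter) and so leaves compound 2 and compound 4 indistinguishable in this read-out. Within the data shown here, the only earlier step exchanged one halogen for another, whereas this one removes both chlorine atoms and brings in a methoxy oxygen, so the arm at this position can lose its halogens altogether and the number stays within the scatter, at least with the 4-methylbenzyl group that compound 2 and compound 4 share. Nothing at hand accounts for this tolerance.

The compounds shown leave open whether the same holds for an unsubstituted benzyl group, for a longer chain such as phenethyl, or for a phenyl ring carrying an amine or a carboxylic acid at this position. They also leave open whether the 4-methylbenzyl group of compound 2 and compound 4 has any part in these low numbers, as no single exchange of that group appears among them.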